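Stereocentre inversion in the amide side chain

The source may hold more compounds than are shown below. What is called first, only, known or untested is meant among the compounds shown, and "the series" means these compounds.

compound 1 (`C[C@@]1(c2ccc3sccc3c2)CC(=O)N(Cc2cccc(C(=O)NCc3ccccc3)c2)C(=N)N1`) gives 23.7 ng.h/mL
compound 2 (`CC(C)[C@]1(C)CC(=O)N(Cc2cccc(C(=O)N[C@@H](C)c3ccccc3)c2)C(=N)N1`) gives 165 ng.h/mL

In an ADME assay on the whole organism (plasma) for pharmacokinetics, with Rattus norvegicus as the target, with a stated time of 6 h, at a dose of 10 mg/kg by the oral route (on this read-out lower numbers stand for lower exposure and higher numbers for higher exposure at the dose given), compound 2 holds the higher of the two numbers and compound 1 the lower, a gap beyond the scatter. Going by the values given here, these two compounds do not differ in one place, so no measured step serves as a precedent. Compound 3 (`CC(C)[C@]1(C)CC(=O)N(Cc2cccc(C(=O)N[C@H](C)c3ccccc3)c2)C(=N)N1`) is the next case: the two compounds have the same atoms and bonds; at least one stereo element is drawn with a configuration in one of them and without one in the other: 1 of 3 stereo elements differ; a stereocentre at a saturated chain carbon is drawn S in compound 2 and R in compound 3, and a stereocentre at a saturated chain carbon is drawn S in compound 2 and R in compound 3. In this assay no step beyond the scatter is expected, with a slight lean towards a lower number. The estimated 1.3-fold lower number from compound 2 to compound 3 (0.10 log units; within the scatter) stays within the scatter. The value expected for compound 3 is 130 ng.h/mL, with an estimated range of 45 ng.h/mL to 330 ng.h/mL.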

Compound 3, area under the concentration-time curve: 70.3 ng.h/mL
Compound 3: middle estimate off by 1.8-fold (0.27 log units), on the high side; the range from low to high includes it.
By their numbers in this assay, from the lowest: compound 1; then compound 3; then compound 2.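

In this assay, changing only the saturated chain carbon of the amide side chain from S to R gives a 2.3-fold lower number from compound 2 to compound 3 (0.37 log units; beyond the scatter), so the configuration at this stereocentre alone shifts exposure beyond the scatter, with atoms and bonds unchanged. Compound 1 and compound 2 differ in more than one place and could not isolate this. The reading carries one caveat: the fact that one of compounds 2 and 3 is drawn with a defined configuration and the other without, at the place where they differ

Going by these compounds, whether the same preference holds on the core of compound 1 remains open. Also open, on these data alone, is how a longer chain or a carboxylic acid at this stereocentre would affect exposure.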